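Swapping bromo for chloro in a thiourea pair

The compounds below may be only part of what the source reports. "The series", "measured", "known", "first", "only" and "open" are said of these compounds alone.

Values in a functional assay on B16-F10 cells (Mus musculus) for inhibition, read by MTT assay, with a stated time of 72 h (a higher number here means a weaker inhibitor, a lower number a stronger inhibitor), for three compounds

Compound 1 `COc1ccc(NC(=S)NC2CC(C)(C)Oc3ccc(Br)cc32)cc1` gives "not determined" (no result reported)
Compound 2 `CC1(C)CC(NC(=S)Nc2ccc(C#N)cc2)c2cc(Cl)ccc2O1` gives 7000 nM
Compound 3 `CC1(C)CC(NC(=S)Nc2ccc([N+](=O)[O-])cc2)c2cc(Br)ccc2O1` gives 3000 nM

Compound 3 (3000 nM) holds the lower of the two actual numbers and so is the stronger inhibitor of the two. Compound 2 (7000 nM) sits higher, by a gap beyond the usual scatter. Compound 1 has no number to compare.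

The next step leads to compound 4 `CC1(C)CC(NC(=S)Nc2ccc([N+](=O)[O-])cc2)c2cc(Cl)ccc2O1`, which puts chloro in place of bromo on an aromatic carbon and leaves the rest of compound 3 unchanged. Among the compounds with values here, no measured pair shows this swap alone. Within the data shown here, compound 2 (7000 nM) is the only measured chloro compound, but it also carries a nitrile where compound 3 has a nitro group, so it gives only a weak hint towards a higher number. The expected change is a 1.3-fold higher number from compound 3 to compound 4 (0.12 log units; within the scatter) and should stay within the scatter of this assay with at most a slight drift upwards. Compound 4 is estimated at 4000 nM with an expected range from 1500 nM to 10000 nM in this assay.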

Compound 4, half-maximal inhibitory concentration: 3000 nM
Estimate against measurement, compound 4: 1.3-fold (0.12 log units) above, and the stated range covers the measured number.
By their numbers in this assay, from the lowest: compounds 3 and 4 (each within the scatter of the next); then compound 2.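

In this assay, chloro in place of bromo on this aromatic carbon gives no change at the digits printed from compound 3 to compound 4 (within the scatter), so with the nitro group present, the two halogens cannot be told apart here. Within the data shown here, with chloro now held constant, nitro in place of cyano gives a 2.3-fold lower number from compound 2 to compound 4 (0.37 log units; beyond the scatter), the first single-place change to lie beyond the scatter, though it remains modest. The data offer no measured explanation for either step.

The compounds shown carry only bromo or chloro at this place, so it remains open how fluoro or an amine would behave there. It is also unknown whether a carboxylic acid in place of the nitro group would give a higher or a lower number, or whether the nitro-for-cyano step would look the same with bromo present.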